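Swapping ethyl for tert-butyl on the amine of compound 2

The compounds below may be only part of what the source reports. "The series", "measured", "known", "first", "only" and "open" are said of these compounds alone.

The series is read in an ADME assay on microsomes from liver (Rattus norvegicus) for metabolic stability, read by LC-MS, with a stated time of 30 min, tested at 1 uM; a higher number here means that more of the compound is left, a lower number that less of the compound is left. Compound 1 `Cc1cc(CNC(C)(C)C)c(O)c(Nc2nc3cc(F)c(F)cc3n2Cc2ccc(C(F)(F)F)cc2)c1` gives 89%, compound 3 `Cc1cc(CNC(C)(C)C)c(O)c(Nc2nc3ccccc3n2Cc2ccc(C(F)(F)F)cc2)c1` gives 41%, and compound 2 `CCNCc1cc(Cl)cc(Nc2nc3ccccc3n2Cc2ccc(C(F)(F)F)cc2)c1O` gives 66%, the second highest of the three numbers, with compound 1 beyond the scatter above it and compound 3 beyond the scatter below it. Compound 4 `CC(C)(C)NCc1cc(Cl)cc(Nc2nc3ccccc3n2Cc2ccc(C(F)(F)F)cc2)c1O` has not been measured; its change from compound 2 is tert-butyl in place of ethyl on an amine nitrogen. Among the measured compounds shown here, no measured pair shows this same change. Compound 3, which also carries the tert-butyl group, gives 41%, so a downward step is expected, of a size near the scatter, printed as a number 11 percentage points lower from compound 2 to compound 4 (beyond the scatter). Compound 4 is therefore estimated at 55%, within a range from 30% to 80%.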

Compound 4, percent of the compound remaining: 9%
Estimate against measurement, compound 4: 46 percentage points above; measured number outside the range, below it.
By their numbers in this assay, from the lowest: compound 4; then compound 3; then compound 2; then compound 1.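

In this assay tert-butyl in place of ethyl on an amine nitrogen brings a large fall (a number 57 percentage points lower from compound 2 to compound 4 (beyond the scatter)), so the group at this position weighs heavily when chloro is present. Chloro in place of methyl on an aromatic carbon, with tert-butyl kept, also brings a large fall (a number 32 percentage points lower from compound 3 to compound 4 (beyond the scatter)). Nothing at hand gives a reason for either step. The compounds shown leave open where isopropyl on the amine nitrogen would fall, and whether ethyl and tert-butyl differ as much with methyl in place of chloro.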